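Chloro in place of hydrogen: compound 1 to compound 3

The compounds below may be only part of what the source reports. "The series", "measured", "known", "first", "only" and "open" are said of these compounds alone.

Within the data shown here, compound 1 `COc1cc(C2CC(c3ccccc3)=NN2c2ccc(-c3ccccc3)nn2)cc(OC)c1OC` holds the only number in the set: in a functional assay on A549 cells (Homo sapiens) for antiproliferative activity, read by MTT assay, with a stated time of 24 h (a lower number here means a stronger inhibitor, a higher number a weaker inhibitor), compound 1 gives 83800 nM. Compound 2 `FC(F)(F)c1ccc(C2CC(c3ccc(Cl)cc3)=NN2c2ccc(-c3ccccc3)nn2)cc1` gives a limit of the assay, > 100000 nM in this assay, not a number. Compound 3 `COc1cc(C2CC(c3ccc(Cl)cc3)=NN2c2ccc(-c3ccccc3)nn2)cc(OC)c1OC` is not yet measured. Compound 3 differs from compound 1 by chloro in place of hydrogen on an aromatic carbon. Among the measured compounds shown here, no measured pair isolates this change, so its step size is unknown; the shift from compound 1 to compound 3 is expected to stay within the usual scatter, with no clear direction. Compound 3 is expected near 90000 nM, within 40000 nM to 200000 nM. The expected step is a 1.1-fold higher number from compound 1 to compound 3 (0.03 log units; within the scatter).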

Compound 3, half-maximal inhibitory concentration: 83300 nM
Estimate against measurement, compound 3: 1.1-fold (0.03 log units) above; the range from low to high includes it.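

Phenyl to 4-chlorophenyl in this assay gives a 1.0-fold lower number from compound 1 to compound 3 (0.00 log units; within the scatter) and so, with 3,4,5-trimethoxyphenyl held on the saturated ring carbon, chloro on this aromatic carbon leaves the reading within the scatter. Exchanging 4-(trifluoromethyl)phenyl for 3,4,5-trimethoxyphenyl gives an at least 1.2-fold lower number from compound 2 to compound 3 (0.07 log units; that floor lies within the scatter) and, as a floor only, sets no size for that change. Compound 2 stands at a limit of the assay, not a number: the limit of > 100000 nM in this assay, at which 1 of the 3 values shown sits.

Open, from the compounds shown here alone, is whether an amine or a carboxylic acid in place of the chloro of compound 3 would move the reading beyond the scatter.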